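Ethylamino for ethylsulfanyl on the hydroxylated chain

The compounds below may be only part of what the source reports. "The series", "measured", "known", "first", "only" and "open" are said of these compounds alone.

Compound 1 `CCSC(=O)/C=C(C)/C=C/CC(C)CCCC(C)C` gives 7.98 in a physicochemical assay for lipophilicity; on this read-out higher numbers stand for higher lipophilicity and lower numbers for lower lipophilicity. Compound 2 `CCNC(=O)/C=C(C)/C=C/CC(C)CCCC(C)C` carries ethylamino in place of ethylsulfanyl on a carbonyl carbon and gives 5.24 in this assay; the step of a number 2.74 log units lower from compound 1 to compound 2 (beyond the scatter). Compound 3 `CCSC(=O)/C=C(C)/C=C/CC(C)CCCC(C)(C)O` differs from compound 1 in a second way, (hydroxy in place of hydrogen on a saturated chain carbon bound to three saturated chain carbons); in this assay compound 3 gives 5.89; the step of a number 2.09 log units lower from compound 1 to compound 3 (beyond the scatter). Compound 3 stands between the two, with compound 2 nearest and compound 1 furthest.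

Compound 4 `CCNC(=O)/C=C(C)/C=C/CC(C)CCCC(C)(C)O` has not been measured. Among the measured compounds shown here, it differs from compound 3 by ethylamino in place of ethylsulfanyl on a carbonyl carbon, the same change as the one from compound 1 to compound 2, at a place described in the same words. The two cores differ by hydroxy in place of hydrogen on a saturated chain carbon bound to three saturated chain carbons.

For the measured compounds named here, the expected step of a number 2.74 log units lower from compound 3 to compound 4 (beyond the scatter) rests on the measured step of a number 2.74 log units lower from compound 1 to compound 2 (beyond the scatter), the single earlier instance of this change; with only one instance, the transfer to the hydroxylated core is an assumption. Compound 4 is expected to give 3.15 in this assay, with the interval from 2.5 to 3.8.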

Compound 4, partition coefficient: 3.15
Compound 4: the middle estimate sits on the measured number at the digits printed; the range from low to high includes it.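

In this assay the ethylamino change on the hydroxylated core gives a number 2.74 log units lower from compound 3 to compound 4 (beyond the scatter), matching at the printed digits a number 2.74 log units lower from compound 1 to compound 2 (beyond the scatter), and the hydroxy change likewise gives a number 2.09 log units lower from compound 2 to compound 4 (beyond the scatter), matching a number 2.09 log units lower from compound 1 to compound 3 (beyond the scatter), so within these four compounds the two changes behave as additive. These two matches are one result rather than two, since the same four numbers close a single square, and they show the transfer only between a core with hydroxy and one with hydrogen at that saturated chain carbon, not to cores that differ in any other way. Nothing available bears on why the steps agree.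

The compounds shown leave open whether the step keeps its size when the chain carbon carries an amine or a carboxylic acid in place of hydroxy. They also leave open how a longer chain than ethyl on the amide nitrogen, or an ethoxy group on the carbonyl carbon, would fit this square.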